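The source may hold more compounds than are shown below. What is called first, only, known or untested is meant among the compounds shown, and "the series" means these compounds.

- Compound 1 `C=C1[C@H](O)[C@@H](O)[C@@H](O)C(C)(C)/C=C/[C@H](C)[C@H](OC(=O)c2ccccc2)[C@@]2(O)C[C@@](C)(O)[C@H](OC(C)=O)[C@@H]2[C@H]1OCC(C)C`: > 100000 nM
- Compound 2 `C=C1[C@H](O)[C@@H](OC(=O)C(C)(C)C)[C@@H](O)C(C)(C)/C=C/[C@H](C)[C@H](OC(=O)c2ccccc2)[C@@]2(O)C[C@@](C)(O)[C@H](OC(C)=O)[C@@H]2[C@H]1OCC(C)C`: 64200 nM

In a functional assay on NCI/ADR-RES cells (Homo sapiens) for positive allosteric modulation, read by MTT assay, with a stated time of 48 h, tested at 10 uM (on this read-out lower numbers stand for stronger inhibition and higher numbers for weaker inhibition), compound 1 gives > 100000 nM, which is a limit and not a number. Compound 3 `C=C1[C@H](OC(=O)c2cccc(C)c2)[C@@H](O)[C@@H](O)C(C)(C)/C=C/[C@H](C)[C@H](OC(=O)c2ccccc2)[C@@]2(O)C[C@@](C)(O)[C@H](OC(C)=O)[C@@H]2[C@H]1OCC(C)C` has (3-methylphenyl)carbonyl in place of hydrogen on an oxygen on a saturated carbon, so a hydroxy becomes ((3-methylphenyl)carbonyl)oxy: (3-methylphenyl)carbonyl in place of hydrogen on an oxygen on a saturated carbon.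

Among the measured compounds shown here, only one measured step is of this kind, with (tert-butyl)carbonyl as the incoming group: an at least 1.5-fold lower number from compound 1 to compound 2 (0.19 log units; that floor lies within the scatter). From the compounds shown here alone, that step starts from the limit of > 100000 nM in this assay, at which 1 of the 2 values shown sits, so its true size is unknown. The incoming group also differs here, which makes it a weak guide. A modest move towards a lower number is therefore expected, and the reading may stay at the limit. The expected step is an at least 1.6-fold lower number from compound 1 to compound 3 (0.22 log units; that floor lies within the scatter). The estimate for compound 3 is 60000 nM, with an expected range from 20000 nM to 100000 nM.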

Compound 3, half-maximal inhibitory concentration: 6600 nM
Compound 3: middle estimate off by 9.1-fold (0.96 log units), on the high side; measured number below the stated range.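

Replacing the hydrogen of this hydroxy with (3-methylphenyl)carbonyl, which turns it into an ester, gives an at least 15-fold lower number from compound 1 to compound 3 (1.18 log units; beyond the scatter) in this assay. Unlike the earlier step, whose floor lay within the scatter, this one shows that a single ester on an oxygen of the shared core can produce a change clearly larger than assay noise. Its size is only a floor, and the true change may be larger, because the step starts from a limit: the limit of > 100000 nM in this assay, at which 1 of the 3 values shown sits.

Compound 2 and compound 3 carry their esters on different oxygens, so they do not show how the two groups rank at one site. From the compounds shown here alone, it also remains open whether the ring's methyl matters, and whether a plain phenylcarbonyl, a small acetyl or a chain bearing an amine on this oxygen would give a similar reading.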